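Compound 2 to compound 4: pentyl in place of phenyl

This account rests on a few compounds, and the source may have more. Where it says the series, first, only, none or still open, it means among the compounds named here.

Of the compounds shown here, three have been measured so far in an ADME assay on MT4 cells (Homo sapiens) for cytotoxicity, read by MTT assay; a lower number here means that less compound is tolerated, a higher number that more compound is tolerated. Compound 1 (`CC(C)C1C(=O)N(O)C(=O)c2ccccc21`) gives 123000 nM as its half-maximal cytotoxic concentration, compound 2 (`O=c1c2ccccc2c(Cc2ccccc2)c(O)n1O`) gives 88000 nM on the same read-out, and compound 3 (`O=C1c2ccccc2C(CCc2ccccc2)C(=O)N1O`) gives 30000 nM there. Compound 2 cannot be told apart from compound 1 on these numbers, since the two lie within the scatter, while compound 3 stands lower than compound 2 by more than the scatter.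

Compound 4 (`CCCCCCc1c(O)n(O)c(=O)c2ccccc12`) is still unmeasured. It keeps the shared core of compound 2 and carries pentyl in place of phenyl on a saturated chain carbon bound to an aromatic carbon.

Going by the values given here, no two measured compounds differ in one place only, so the series gives no direct measure of such a step. The expectation in this assay is a modest fall just beyond the scatter, towards less compound tolerated. It leans on compound 3 (30000 nM) as the only measured lower reference, and no drop far past that number is expected. The estimated change is a 2.5-fold lower number from compound 2 to compound 4 (0.40 log units; beyond the scatter) on this basis. For compound 4 the estimated value is 35000 nM (expected range 12000 nM to 100000 nM).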

Compound 4, half-maximal cytotoxic concentration: 128000 nM
Compound 4: middle estimate off by 3.7-fold (0.56 log units), on the low side; the measured number lies above the stated range.
By their numbers in this assay, from the lowest: compound 3; then compounds 2, 1 and 4 (each within the scatter of the next).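

In this assay, going by these compounds alone, exchanging phenyl for pentyl on a saturated chain carbon bound to an aromatic carbon gives a 1.5-fold higher number from compound 2 to compound 4 (0.16 log units; within the scatter), the first step that changes one place only. At this position, the loss of the six-membered aromatic ring of carbon only and the entry of an open chain leave the number within the scatter, so in this pair the ring is not required for the tolerance seen with compound 2, and pentyl brings no measurable loss of it. No measured information available here accounts for this flat result.

A single pair cannot show whether the position stays this flat for other groups, and a longer chain such as octyl, an amine or a carboxylic acid in the same place would test that in this assay. From the compounds shown here alone, compound 3 stands lower than compound 2 but differs from it in more than one place, so what drives its lower number stays open, and no change can yet be tied to a fall in tolerance.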